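Methoxy for methylsulfanyl on a second core

The source may hold more compounds than are shown below. What is called first, only, known or untested is meant among the compounds shown, and "the series" means these compounds.

The measured compounds and their values:
compound 1, `CSc1ccc(CNc2nc(SC)nc3ncccc23)cc1`, gives 3770 nM in an ADME assay on BEAS-2B cells (Homo sapiens) for cytotoxicity, read by MTT assay, with a stated time of 72 h; a lower number here means a stronger inhibitor of growth, a higher number a weaker inhibitor of growth.
compound 3, `CSc1ccc(CNc2nc([SeH])nc3ccccc23)cc1`, gives 58200 nM in this assay.
compound 2, `COc1ccc(CNc2nc([SeH])nc3ccccc23)cc1`, sits at a limit of the assay in this assay, > 100000 nM.

Compound 1 gives the lowest number among the compounds with a measured value; compound 3 sits a long way from it, beyond the scatter. How the core of compound 1 differs from the core of compound 3 is not broken down here.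

Within the core of compound 3, the change methoxy in place of methylsulfanyl on an aromatic carbon made a step of an at least 1.7-fold higher number from compound 3 to compound 2 (0.23 log units; that floor lies within the scatter). The size of this step can only be given as a floor because of the limit of > 100000 nM in this assay, at which 1 of the 3 values shown sits, so the real step may be larger.

Compound 4, `COc1ccc(CNc2nc(SC)nc3ncccc23)cc1`, has not yet been measured. Among the measured compounds shown here, it carries the change (methoxy in place of methylsulfanyl on an aromatic carbon), the same change as the one from compound 3 to compound 2, made on the core of compound 1 instead. Both compounds involved sit far from the limit, so the step should be visible in full. Compound 4 is expected to give a higher number than compound 1, with a step of about a 2.4-fold higher number from compound 1 to compound 4 (0.38 log units; beyond the scatter), resting on the direction of the step from compound 3 to compound 2 given by an at least 1.7-fold higher number from compound 3 to compound 2 (0.23 log units; that floor lies within the scatter). For compound 4 the estimate in this assay is 9000 nM, between 3500 nM and 25000 nM.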

Compound 4, concentration for total growth inhibition: > 100000 nM
Compound 4 ended at the assay's limit; the forecaster's own chance of this, stated with the estimate: 5%; at least 11-fold (1.04 log units) between middle value and limit.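

On the core of compound 1, methoxy in place of methylsulfanyl on an aromatic carbon made a large step in this assay, an at least 26-fold higher number from compound 1 to compound 4 (1.42 log units; beyond the scatter), and this size is a floor, not a measured gap. Set beside the earlier step on the core of compound 3, this result does not show that a single step size carries from one core to the other, and it does not show that the two cores respond differently: the same change on two cores in this assay, an at least 1.7-fold higher number (0.23 log units; that floor lies within the scatter) from compound 3 to compound 2 and an at least 26-fold higher number (1.42 log units; beyond the scatter) from compound 1 to compound 4; the limit leaves it open whether they differ Neither step has a known upper end, and the true size of each cannot be read, because compound 2 and compound 4 both stand at a limit of the assay: the limit of > 100000 nM in this assay, at which 2 of the 4 values shown sit.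

The compounds shown leave open how other groups at this place on the aromatic ring would read in this assay, for instance a hydroxy group, an ethylsulfanyl group or a longer chain. Among the compounds shown here, they also leave open what the difference between the core of compound 1 and the core of compound 3 contributes on its own, as no step that differs in one place links the two cores.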